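The source may hold more compounds than are shown below. What is called first, only, known or untested is meant among the compounds shown, and "the series" means these compounds.

Compound 3 `COc1c(N2CC[C@@H](CN)C2)c(F)cc2c(=O)c(C(=O)O)cn(Cc3ccc(-n4cccn4)cc3)c12` reports only a limit in an assay on isolated protein for inhibition of DNA topoisomerase 1 (Homo sapiens), with a stated time of 15 min (on this read-out higher numbers stand for weaker inhibition and lower numbers for stronger inhibition), > 200000 nM; this is the limit of > 200000 nM in this assay, at which 1 of the 3 values shown sits. Compound 2 `COc1c(N2CC[C@@H](CN)C2)c(F)cc2c(=O)c(C(=O)O)cn(Cc3ccc(-c4ccccc4)cc3)c12` gives 26000 nM in this assay. The change phenyl in place of 1H-pyrazol-1-yl on an aromatic carbon therefore produces an at least 7.6-fold lower number from compound 3 to compound 2 (0.88 log units; beyond the scatter). Compound 1 `NC[C@@H]1CCN(c2ccc3c(=O)c(C(=O)O)cn(Cc4ccc(-n5cccn5)cc4)c3c2)C1` gives 61000 nM in this assay; how its core differs from that of compound 3 is not broken down here. Compound 4 `NC[C@@H]1CCN(c2ccc3c(=O)c(C(=O)O)cn(Cc4ccc(-c5ccccc5)cc4)c3c2)C1` carries the same change as compound 2 does, (phenyl in place of 1H-pyrazol-1-yl on an aromatic carbon), on the core of compound 1. Since the same change gave an at least 7.6-fold lower number from compound 3 to compound 2 (0.88 log units; beyond the scatter), a step of similar direction is expected for compound 4, though the earlier step is only known as a minimum and the cores differ, so a somewhat smaller step is taken as the expectation: a 6.1-fold lower number from compound 1 to compound 4 (0.79 log units; beyond the scatter). Compound 4 is thus estimated at 10000 nM in this assay, expected to fall between 3000 nM and 35000 nM.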

Compound 4, half-maximal inhibitory concentration: 61200 nM
Compound 4: middle estimate off by 6.1-fold (0.79 log units), on the low side; the measured number lies above the stated range.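

In this assay, the change from 1H-pyrazol-1-yl to phenyl does not carry over between these two cores with the same effect: the same change on two cores in this assay, an at least 7.6-fold lower number (0.88 log units; beyond the scatter) from compound 3 to compound 2 and a 1.0-fold higher number (0.00 log units; within the scatter) from compound 1 to compound 4, at least 7.7-fold (0.88 log units) apart, beyond the scatter of two such steps. On the core of compound 1 the new step reads a 1.0-fold higher number from compound 1 to compound 4 (0.00 log units; within the scatter), so the two groups cannot be told apart there. Compound 3 gives > 200000 nM, which is a limit of the assay and not a number, so the earlier step is known only as a minimum, and the data do not show which feature of the two cores sets the gap.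

As far as these compounds go, whether the gap would hold on a third core stays open. So does what a pyridine ring or a cyclohexyl group would give in place of phenyl on either core.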